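Flipping One Ring Stereocentre in a Hydroxamate Series

The source may report more compounds than this note shows. Statements on the series, on what has been measured and on what is new or still open speak of the compounds shown alone.

Three measured compounds set the scene. In an assay on Sf9 cells for inhibition of histone deacetylase 11 (Homo sapiens), read by fluorescence, tested at 0.5 uM (on this read-out higher numbers stand for more inhibition at the one concentration tested (going by the name of the read-out) and lower numbers for less inhibition), compound 1 `O=C(NO)c1cccc(-c2cn([C@H]3C[C@H](C(=O)O)N(Cc4ccccc4)C3)nn2)c1` is reported only as a limit, < 10%. Compound 3 `O=C(NO)c1ccc(-c2cn([C@@H]3C[C@H](CO)N(CCCc4ccccc4)C3)nn2)cc1` gives 15% in this assay. Compound 2 `O=C(/C=C/c1cn([C@@H]2C[C@@H](CO)N(Cc3ccccc3)C2)nn1)NO` likewise stands at a limit of the assay rather than a number, < 10%, which is the limit of < 10% in this assay, at which 2 of the 3 values shown sit.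

Compound 4 `O=C(/C=C/c1cn([C@H]2C[C@@H](CO)N(Cc3ccccc3)C2)nn1)NO` has not yet been measured. Its difference from compound 2 is the two compounds have the same atoms and bonds and differ only in configuration as drawn: 1 of 3 stereo elements differ; a stereocentre at a saturated ring carbon is drawn R in compound 2 and S in compound 4. Among the measured compounds shown here, no measured pair here differs in only one place, so no measured step guides this change. Because compound 2 sits at < 10%, the step from compound 2 to compound 4 in this assay is expected to be a step that the limit leaves unreadable from compound 2 to compound 4, nothing beyond the scatter. Compound 4 is estimated at 5%, within 0% to 15%, most likely reported again only as a limit.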

Compound 4, a percentage reported as inhibition, at one concentration (the size of the read-out at that concentration, not a potency): 35%
Compound 4: the middle estimate sits 30 percentage points below what was measured, and the stated range ends below it.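

In this assay, turning this one saturated ring carbon from R to S gives a number at least 25 percentage points higher from compound 2 to compound 4 (beyond the scatter). Among the compounds shown here, this is the first single-change step, and it shows that configuration at this position alone can lift the read-out clear of the assay limit: the fact that compounds 2 and 4 differ only in the configuration as drawn. As far as these compounds go, the true size of the step stays open-ended, since the starting point is a limit and not a number: the limit of < 10% in this assay, at which 2 of the 4 values shown sit. The compounds shown leave open whether the same flip would raise the read-out with an amine in place of the hydroxymethyl group, and what the other ring stereocentre contributes on its own.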